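The compounds below may be only part of what the source reports. "The series", "measured", "known", "first", "only" and "open" are said of these compounds alone.

Measured in a functional assay on HeLa cells (Homo sapiens) for antiproliferative activity, read by MTT assay, with a stated time of 48 h; on this read-out lower numbers stand for stronger inhibition and higher numbers for weaker inhibition:
- compound 1 `COc1ccc(C(=O)c2ccc(OC)c3c2OC(C)(C)C=C3)c(NC(=O)CO)c1`: 100 nM
- compound 2 `COc1ccc(C(=O)c2ccc(OC)c3c2C=CC(C)(C)O3)c(NC(=O)CO)c1`: 310 nM
- compound 3 `CNCC(=O)Nc1cc(OC)ccc1C(=O)c1ccc2c(c1)C=CC(C)(C)O2`: 970 nM

Compound 1 gives the lowest number of the three, and the gaps to the other two lie beyond the scatter. Compound 4 `CCNCC(=O)Nc1cc(OC)ccc1C(=O)c1ccc(OC)c2c1OC(C)(C)C=C2` keeps the core of compound 1 but has ethylamino in place of hydroxy on a saturated chain carbon bound to a carbonyl carbon. Among the compounds with values here, no measured pair isolates this change. Within the data shown here, the only hint is compound 3, which also has a nitrogen in that chain, though on a different core, and gives 970 nM. A weakening is therefore expected, probably beyond the scatter. The estimated step is a 3.0-fold higher number from compound 1 to compound 4 (0.48 log units; beyond the scatter). For compound 4 the expected value is 300 nM, within an estimated range of 90 nM to 1000 nM.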

Compound 4, half-maximal inhibitory concentration: 2690 nM
For compound 4 the middle estimate is 9.0-fold (0.95 log units) below the measured one; the whole stated range lies below it.
By their numbers in this assay, from the lowest: compound 1; then compound 2; then compound 3; then compound 4.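

On the core of compound 1, ethylamino in place of hydroxy on a saturated chain carbon bound to a carbonyl carbon gives, in this assay, a 27-fold higher number from compound 1 to compound 4 (1.43 log units; beyond the scatter), so this position responds strongly to the change. The two groups count the same hydrogen-bond donors and acceptors, so those counts alone do not separate them. Nothing available here explains the size of this step.

As far as these compounds go, whether the loss follows the nitrogen or the added carbons remains open. A plain amino group or a methoxy group at this place on the shared core would help tell these apart.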